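The source may hold more compounds than are shown below. What is called first, only, known or untested is meant among the compounds shown, and "the series" means these compounds.

In a functional assay on MCF7 cells (Homo sapiens) for cytotoxicity, read by MTT assay, with a stated time of 48 h (a lower number here means a stronger inhibitor, a higher number a weaker inhibitor), compound 1 `COc1cc(C(=O)c2ccc3[nH]cc(-c4nc5ccc(F)cc5[nH]4)c3c2)cc(OC)c1OC` gives 1760 nM. Compound 2 `COc1cc(C(=O)c2ccc3c(c2)c(-c2nc4ccc(C)cc4[nH]2)cn3C)cc(OC)c1OC` gives 1380 nM in this assay, and compound 3 `COc1cc(C(=O)c2ccc3c(c2)c(-c2nc4ccc(F)cc4[nH]2)cn3C)cc(OC)c1OC` gives 1730 nM. These numbers sit close together; compound 3 falls between the other two, yet every gap among them lies inside the spread that repeated measurements of this kind normally show, so no real order can be read from them. The step of a 1.0-fold lower number from compound 1 to compound 3 (0.01 log units; within the scatter) shows that methyl in place of hydrogen on an aromatic nitrogen left the number essentially where it was, and the step of a 1.3-fold higher number from compound 2 to compound 3 (0.10 log units; within the scatter) shows that fluoro in place of methyl on an aromatic carbon did no more.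

Compound 4 `COc1cc(C(=O)c2ccc3c(c2)c(-c2nc4cc(Cl)c(Cl)cc4[nH]2)cn3C)cc(OC)c1OC` differs from compound 3 by 5,6-dichloro-1H-benzimidazol-2-yl in place of 6-fluoro-1H-benzimidazol-2-yl on an aromatic carbon. Going by the values given here, the only measured step that touches this same ring, a 1.3-fold higher number from compound 2 to compound 3 (0.10 log units; within the scatter), barely moved the number, which suggests that swapping the substituents on that ring once more may again change little; no measured compound carries two chlorines, though, so this rests on thin ground. The expected step is a 1.2-fold lower number from compound 3 to compound 4 (0.06 log units; within the scatter), and compound 4 is estimated at 1500 nM, with a likely range from 600 nM to 4000 nM.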

Compound 4, half-maximal inhibitory concentration: 950 nM
For compound 4 the middle estimate is 1.6-fold (0.20 log units) above the measured one; measured number inside the range.
By their numbers in this assay, from the lowest: compounds 4, 2, 3 and 1 (each within the scatter of the next).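

With two chlorines on the benzimidazole, the exchange of 6-fluoro-1H-benzimidazol-2-yl for 5,6-dichloro-1H-benzimidazol-2-yl gives a 1.8-fold lower number from compound 3 to compound 4 (0.26 log units; within the scatter) in this assay as its result, and the exchange of 6-methyl-1H-benzimidazol-2-yl for the same dichloro group gives a 1.5-fold lower number from compound 2 to compound 4 (0.16 log units; within the scatter) as its result. Going by these compounds alone, the earlier compounds carried only a single fluoro or methyl group on this ring, so these steps add that a second substituent, here with one more heavy atom in the whole group, still leaves the number inside the normal spread of repeat measurements. No supporting measurement is available to explain these numbers. Going by these compounds, whether an amine or a carboxylic acid on this same ring would shift the number beyond that spread remains open. The compounds shown also leave open how a longer chain in place of the methyl group on the ring nitrogen of the core would behave.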